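Acid chain lengths on the shared core, compound 3 estimate

The compounds below may be only part of what the source reports. "The series", "measured", "known", "first", "only" and "open" are said of these compounds alone.

Compound 1 `Cc1c(Cl)cccc1CCCCOc1ccc(C#Cc2cccc3c(CCCC(=O)O)c(C)n(CC(=O)O)c23)cc1` and compound 2 `Cc1c(Cl)cccc1CCCCOc1ccc(C#Cc2cccc3c(CC(=O)O)c(C)n(CCCCC(=O)O)c23)cc1` were tested in a functional assay on CHO-K1 cells for antagonist activity at cysteinyl leukotriene receptor 1 (Homo sapiens), read by fluorescence and calcium flux, with stated times of 30 min and 1 h; on this read-out higher numbers stand for weaker inhibition and lower numbers for stronger inhibition. Among the compounds with values here, compound 1 gives 0.22 nM, and compound 2 gives 65 nM, the highest of the two numbers so far and well beyond the scatter of compound 1. Compound 3 `Cc1c(Cl)cccc1CCCCOc1ccc(C#Cc2cccc3c(CC(=O)O)c(C)n(CC(=O)O)c23)cc1` has not yet been measured in this assay. Compound 3 differs from compound 2 in one place: carboxy in place of 3-carboxypropyl on a saturated chain carbon bound to an aromatic nitrogen. Compound 3 therefore carries the same carboxymethyl on the aromatic nitrogen as compound 1, while keeping the shorter chain on the ring carbon that compound 2 has. Within the data shown here, no step between measured compounds is available for this change. The expectation is a step of a 13-fold lower number from compound 2 to compound 3 (1.11 log units; beyond the scatter) in this assay, downward toward stronger inhibition, by more than the scatter. Compound 3 is estimated at 5 nM, with a range from 0.5 nM to 40 nM.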

Compound 3, half-maximal inhibitory concentration: 0.47 nM
The estimate for compound 3 lay 11-fold (1.03 log units) above the measured number; the measured number lies below the stated range.
By their numbers in this assay, from the lowest: compound 1; then compound 3; then compound 2.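

In this assay, shortening the acid chain on the aromatic nitrogen has by far the larger effect: carboxy in place of 3-carboxypropyl on a saturated chain carbon bound to an aromatic nitrogen gives a 140-fold lower number from compound 2 to compound 3 (2.14 log units; beyond the scatter) and counts as a large step. Carboxy in place of 2-carboxyethyl on a saturated chain carbon bound to an aromatic carbon gives a 2.1-fold higher number from compound 1 to compound 3 (0.33 log units; beyond the scatter) and counts as a modest step, though still beyond the scatter. The two acid chains therefore do not weigh equally in these three compounds, and no available measurement gives a reason for either step.

Open, on these data alone, is how the number moves with 2-carboxyethyl on the aromatic nitrogen, a chain length that would fall within the large step. Also open, as far as these compounds go, is whether an amide or a tetrazole can stand in for either carboxylic acid.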